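Cyclohexyl in Place of Cyclopentyl on the Alkene Carbon

This account rests on a few compounds, and the source may have more. Where it says the series, first, only, none or still open, it means among the compounds named here.

Three measured compounds share one core and differ only in the group on a double-bonded chain carbon. Compound 1 `O=C(O)/C=C/c1ccc(/C(=C(/CCF)c2ccccc2)c2ccc3[nH]ncc3c2)cc1` carries a 2-fluoroethyl group there; in a functional assay on MCF7 cells (Homo sapiens) for cytotoxicity, read by CellTiter-Glo, with a stated time of 5 days (on this read-out higher numbers stand for weaker inhibition and lower numbers for stronger inhibition), compound 1 gives 2.1 nM. Compound 2 `CC(C)/C(=C(/c1ccc(/C=C/C(=O)O)cc1)c1ccc2[nH]ncc2c1)c1ccccc1` carries an isopropyl group, and in this assay compound 2 gives 4 nM. Compound 3 `O=C(O)/C=C/c1ccc(/C(=C(\c2ccccc2)C2CCCC2)c2ccc3[nH]ncc3c2)cc1` carries a cyclopentyl group, and in this assay compound 3 gives 10 nM, the highest of the three numbers. The steps among them are a 1.9-fold higher number from compound 1 to compound 2 (0.28 log units; within the scatter), a 4.8-fold higher number from compound 1 to compound 3 (0.68 log units; beyond the scatter) and a 2.5-fold higher number from compound 2 to compound 3 (0.40 log units; beyond the scatter); the two steps that go beyond the scatter both end at the cyclopentyl compound with a higher number.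

Compound 4 `O=C(O)/C=C/c1ccc(/C(=C(\c2ccccc2)C2CCCCC2)c2ccc3[nH]ncc3c2)cc1` continues this series with cyclohexyl in place of cyclopentyl on a double-bonded chain carbon bound to an aromatic carbon and a double-bonded chain carbon. Going by the values given here, the steps that bear on it are a 2.5-fold higher number from compound 2 to compound 3 (0.40 log units; beyond the scatter) and a 4.8-fold higher number from compound 1 to compound 3 (0.68 log units; beyond the scatter), each a modest rise when the group on that carbon was exchanged for a ring. Among the compounds with values here, a step of similar size in the same direction is therefore expected, though with only three measured compounds this is an expectation rather than a rule. In this assay compound 4 is expected to give 20 nM, within a range from 8 nM to 50 nM, which would mean an expected step of a 2.0-fold higher number from compound 3 to compound 4 (0.30 log units; within the scatter).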

Compound 4, half-maximal inhibitory concentration: 64 nM
The estimate for compound 4 lay 3.2-fold (0.51 log units) below the measured number; measured number above the stated range.
By their numbers in this assay, from the lowest: compounds 1 and 2 (each within the scatter of the next); then compound 3; then compound 4.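

The exchange of cyclopentyl for cyclohexyl on this alkene carbon, a change of a single ring carbon, gives in this assay a 6.4-fold higher number from compound 3 to compound 4 (0.81 log units; beyond the scatter) and so shows that the rise at this position does not stop at the cyclopentyl group. Set against the two open-chain groups, the same ring gives the first large steps at this position, with a 16-fold higher number from compound 2 to compound 4 (1.20 log units; beyond the scatter) and a 30-fold higher number from compound 1 to compound 4 (1.48 log units; beyond the scatter) in the same assay series; among these four compounds, the two carbon rings give the highest numbers, cyclohexyl stands above cyclopentyl, and no compound goes against that order. The numbers describe the size of the change but do not explain it, and nothing available here accounts for the rise.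

The compounds shown leave open whether smaller carbon rings, such as cyclopropyl or cyclobutyl, would fall in with this order. They also leave open what a tetrahydropyranyl ring, with an oxygen atom in place of one ring carbon, or a longer straight chain such as n-butyl would give on this carbon.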